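The source may hold more compounds than are shown below. What is called first, only, known or untested is meant among the compounds shown, and "the series" means these compounds.

Measured so far in an ADME assay on microsomes from liver (Homo sapiens) for metabolic stability, read by HPLC, using NADPH, with a stated time of 60 min, tested at 1 uM, in the presence of a further agent that is not named here; a higher number here means faster removal of the compound, a lower number slower removal:
- compound 1 `Cc1cc(-n2cccn2)cc(C(=O)NNS(=O)(=O)c2ccccc2)c1F`: 23 uL/min
- compound 2 `Cc1cc(-c2ccccn2)cc(C(=O)NNS(=O)(=O)c2ccccc2)c1F`: 27 uL/min

Compound 2 is separated from compound 1 only by a 1.2-fold higher number from compound 1 to compound 2 (0.07 log units; within the scatter); on the numbers shown the two compounds are not distinguished in this assay.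

Compound 3 `Cc1cc(-n2nccn2)cc(C(=O)NNS(=O)(=O)c2ccccc2)c1F` differs from compound 2 in one place: 2H-1,2,3-triazol-2-yl in place of pyridin-2-yl on an aromatic carbon. Among the measured compounds shown here, the only step measured so far, from compound 1 to compound 2, also exchanges a five-membered ring bearing nitrogen for pyridin-2-yl at the same position of the shared core, and it was a 1.2-fold higher number from compound 1 to compound 2 (0.07 log units; within the scatter). Reversing that kind of exchange with 2H-1,2,3-triazol-2-yl is therefore expected to give no step beyond the scatter in this assay. For compound 3 the expected value is 24 uL/min, with a range of 12 uL/min to 48 uL/min, meaning an estimated step of a 1.1-fold lower number from compound 2 to compound 3 (0.05 log units; within the scatter).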

Compound 3, intrinsic clearance in a liver preparation (reported as CLH), per the amount of preparation that the assay uses in the Homo sapiens assay: 28 uL/min
Compound 3: the middle estimate sits 1.2-fold (0.07 log units) below what was measured; the measured number falls inside the stated range.
By their numbers in the Homo sapiens assay, from the lowest: compounds 1, 2 and 3 (each within the scatter of the next).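

In the Homo sapiens assay the steps of a 1.0-fold higher number from compound 2 to compound 3 (0.02 log units; within the scatter) and a 1.2-fold higher number from compound 1 to compound 3 (0.09 log units; within the scatter) show a third aromatic ring at the position meta to a methyl group and para to a fluoro group, with no separation from the other two. Moving from one six-membered aromatic ring with 1 hetero atom to one five-membered aromatic ring with 3 hetero atoms therefore leaves no readable change in this assay, where the earlier step compared only two rings. In a physicochemical assay for solubility, read by nephelometry, measured as kinetic solubility, at pH 2 (a lower number here means a less soluble compound, a higher number a more soluble compound), compound 2 gives 50 ug/mL and compound 3 gives 25 ug/mL as a pair within the scatter of each other, so this exchange is not resolved there either.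

As far as these compounds go, whether a saturated amine or a carboxylic acid at this position would shift either read-out remains open. Nothing available accounts for these level readings.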